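The compounds below may be only part of what the source reports. "The series", "measured", "known", "first", "only" and "open" are said of these compounds alone.

In a functional assay on M21 cells (Homo sapiens) for antiproliferative activity, read by sulforhodamine B assay, with a stated time of 48 h (on this read-out lower numbers stand for stronger inhibition and higher numbers for weaker inhibition), compound 1 (`CCc1ccccc1NS(=O)(=O)c1ccc(N2CCNC2=O)cc1`) gives 180 nM and compound 2 (`O=C1NCCN1c1ccc(S(=O)(=O)Nc2ccc(F)cc2)cc1`) gives 230 nM with no real gap between them, since the two lie within the usual scatter. Compound 3 (`Cc1ccc(NS(=O)(=O)c2ccc(N3CCNC3=O)cc2)cc1C`) keeps the shared core and carries 3,4-dimethylphenyl in place of 4-fluorophenyl on a sulfonamide nitrogen. Going by the values given here, the one measured step that changes the group at this place is a 1.3-fold higher number from compound 1 to compound 2 (0.11 log units; within the scatter) and it stays within the scatter, so a swap here has moved the number little so far, though one step is thin evidence. The expected step of a 1.2-fold lower number from compound 2 to compound 3 (0.06 log units; within the scatter) is therefore no larger than the scatter. For compound 3 the estimated value is 200 nM with an expected range from 80 nM to 500 nM in this measurement.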

Compound 3, half-maximal inhibitory concentration: 94 nM
The estimate for compound 3 lay 2.1-fold (0.33 log units) above the measured number; measured number inside the range.
By their numbers in this assay, from the lowest: compounds 3, 1 and 2 (each within the scatter of the next, the first and the last beyond it).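

Going by these compounds alone, on a sulfonamide nitrogen, the group can move the number in this assay: 3,4-dimethylphenyl in place of 4-fluorophenyl gives a 2.4-fold lower number from compound 2 to compound 3 (0.39 log units; beyond the scatter) as the first step at this place beyond the scatter, though a modest one. In place of 2-ethylphenyl, the same group gives a 1.9-fold lower number from compound 1 to compound 3 (0.28 log units; within the scatter) and stays within the scatter, so it stands clearly apart from 4-fluorophenyl only. No evidence is at hand to explain this gap. From the compounds shown here alone, whether a phenyl ring carrying an amine or a carboxylic acid would keep these numbers remains open.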